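Aryl carbamate in a weak sulfamate series

A few compounds are considered here, and "the series" means these few. Any claim that something is new, unique, unknown or untested is made for them only; others in the source may bear on it.

Measured compounds:
Compound 1 `CCOC(=O)NS(=O)(=O)Oc1c(C(C)C)cccc1C(C)C` – > 50000 nM; > 50000 nM (2 entries) in an assay on liver for inhibition of sterol O-acyltransferase 1 (Rattus norvegicus), using microsomes (on this read-out higher numbers stand for weaker inhibition and lower numbers for stronger inhibition), reported as a limit of the assay rather than a number
Compound 2 `CC(C)c1cccc(C(C)C)c1OS(=O)(=O)NC(=O)OC1CCCCC1` – 38000 nM
Compound 3 `CC(C)c1cccc(C(C)C)c1OS(=O)(=O)NC(=O)O[C@@H]1C[C@H](C)CCC1C(C)C` – 21000 nM

All three share one core carrying a sulfamate group joined to a carbamate. Compound 1 gives only a limit in this assay. Compound 2 and compound 3 give numbers, and those numbers sit close together: the step of a 1.8-fold lower number from compound 2 to compound 3 (0.26 log units; within the scatter) lies within the scatter, so neither can be called the stronger of the two on this evidence.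

Compound 4 `CC(C)c1cccc(C(C)C)c1OS(=O)(=O)NC(=O)Oc1ccc(F)cc1F` has not yet been measured. The difference from compound 3 is 2,4-difluorophenyl in place of 2-isopropyl-5-methylcyclohexyl on an oxygen next to a carbonyl group. Within the data shown here, the only measured step at that position, the step from compound 2 to compound 3, exchanged one saturated ring for another and stayed within the scatter. Among the measured compounds shown here, no measured step exchanges a saturated ring for an aromatic one, so nothing here points to a shift beyond the scatter. Compound 4 is therefore expected to sit near compound 3, with an expected step of a 1.2-fold higher number from compound 3 to compound 4 (0.08 log units; within the scatter). The estimate for compound 4 is 25000 nM, within the range 8000 nM to 100000 nM.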

Compound 4, half-maximal inhibitory concentration: > 50000 nM
Compound 4 was reported as a limit (the forecaster's own chance of this, stated with the estimate: 30%); at least 2.0-fold (0.30 log units) between middle value and limit.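

In this assay compound 4 gives > 50000 nM, which is a limit of the assay and not a number. On an oxygen next to a carbonyl group, exchanging a saturated ring for an aromatic one gives an at least 2.3-fold higher number from compound 3 to compound 4 (0.37 log units; beyond the scatter), so 2,4-difluorophenyl weakens inhibition relative to 2-isopropyl-5-methylcyclohexyl, while the swap of one saturated ring for another stayed within the scatter. Against the smaller cyclohexyl the result is less firm, with an at least 1.3-fold higher number from compound 2 to compound 4 (0.11 log units; that floor lies within the scatter), so this pair cannot be told apart on the floor alone.

The compounds shown leave open whether the aromatic ring itself or its two fluorine atoms matter, a question that plain phenyl at this place could help separate. Also open, on these data alone, is how a straight carbon chain such as octyl would compare with these rings.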